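A Carbamate in Place of the Hydroxyl Chain

A few compounds are considered here, and "the series" means these few. Any claim that something is new, unique, unknown or untested is made for them only; others in the source may bear on it.

Of the compounds shown here, three sharing one core have been tested in an assay on CHO cells for agonist activity at 5-hydroxytryptamine receptor 1D (Homo sapiens), read by GTPgammaS binding; a lower number here means that less compound is needed, a higher number that more compound is needed for the effect. Compound 1 `O[C@@H]1Cc2ccccc2[C@H]1NC1CCN(CCCc2c[nH]c3ccc(-n4cnnc4)cc23)CC1` gives 13 nM. Compound 2 `c1ccc2c(c1)CCC2NC1CCN(CCCc2c[nH]c3ccc(-n4cnnc4)cc23)CC1`, which lacks the hydroxyl on its bicyclic ring, gives 25 nM. Compound 3 `OCCC(NC1CCN(CCCc2c[nH]c3ccc(-n4cnnc4)cc23)CC1)c1ccccc1`, in which the bicyclic ring is opened into a phenyl ring with a hydroxyl-bearing chain, gives 5.1 nM and so shows the lowest number of the three. The steps leading to it were a 2.5-fold lower number from compound 1 to compound 3 (0.41 log units; beyond the scatter) and a 4.9-fold lower number from compound 2 to compound 3 (0.69 log units; beyond the scatter), while a 1.9-fold higher number from compound 1 to compound 2 (0.28 log units; within the scatter).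

Compound 4 `NC(=O)OC[C@H](NC1CCN(CCCc2c[nH]c3ccc(-n4cnnc4)cc23)CC1)c1ccccc1` is the next variation: 2-(carbamoyloxy)-1-phenylethyl in place of 3-hydroxy-1-phenylpropyl on an amine nitrogen. The hydroxyl on the chain is thus replaced by a carbamate ester, the chain is shortened, and one hydrogen-bond donor remains while a second acceptor appears. Going by the values given here, the only steps that bear on this are those opening the ring toward compound 3, which were modest and both favourable; nothing measured yet tests a change of the chain itself. On that basis the step of a 1.4-fold higher number from compound 3 to compound 4 (0.14 log units; within the scatter) is expected to stay small, within or close to the scatter, in either direction. Compound 4 is therefore estimated at 7 nM, with a range from 2.5 nM to 20 nM.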

Compound 4, half-maximal effective concentration: 9.3 nM
Beside the measured number, compound 4's estimate is 1.3-fold (0.12 log units) below it; the measured number falls inside the stated range.
By their numbers in this assay, from the lowest: compounds 3, 4, 1 and 2 (each within the scatter of the next, the first and the last beyond it).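

In this assay the amine nitrogen, whose other neighbour is a saturated ring carbon, takes 2-(carbamoyloxy)-1-phenylethyl in place of 3-hydroxy-1-phenylpropyl with little effect on the number (a 1.8-fold higher number from compound 3 to compound 4 (0.26 log units; within the scatter)), so the open-chain series need not end in a hydroxyl to stay in this range. Measured against the ring compounds, the new group keeps a modest advantage over the ring without a hydroxyl (a 2.7-fold lower number from compound 2 to compound 4 (0.43 log units; beyond the scatter)), while it cannot be told apart from the ring with a hydroxyl (a 1.4-fold lower number from compound 1 to compound 4 (0.15 log units; within the scatter)). No measurement here explains why the carbamate is accepted at this position.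

Going by these compounds, this one step changes the end group and shortens the chain together, and it also brings a defined stereocentre, so the share of each change in the result stays unknown. A longer chain ending in the same carbamate, a chain of the same length ending in an amine or a carboxylic acid, and the mirror-image form of compound 4 would each help to separate these contributions.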